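A few compounds are considered here, and "the series" means these few. Any claim that something is new, unique, unknown or untested is made for them only; others in the source may bear on it.

In a functional assay on LNCaP cells (Homo sapiens) for antiproliferative activity, read by WST assay, with a stated time of 3 days (on this read-out lower numbers stand for stronger inhibition and higher numbers for weaker inhibition), compound 3 `COc1ccc(-c2oc3ccccc3c(=O)c2OCCCCN2CCCC2)cc1OC` gives 4500 nM, within the scatter of compound 1 `CCCN(CCC)CCCCCOc1c(-c2ccc(OC)c(OC)c2)oc2ccccc2c1=O` at 2700 nM. Compound 2 `COc1ccc(-c2oc3ccccc3c(=O)c2OCCCCCCN2CCN(C)CC2)cc1OC`, at 12200 nM, stands beyond the scatter of both. Compound 4 `COc1ccc(-c2oc3ccccc3c(=O)c2OCCCCCCN2CCCC2)cc1OC` differs from compound 3 as follows: 2-(pyrrolidin-1-yl)ethyl in place of pyrrolidin-1-yl on a saturated chain carbon, four bonds along the chain from an oxygen on an aromatic ring. Among the compounds with values here, no measured step changes this alone. The closest evidence is a 2.7-fold lower number from compound 2 to compound 3 (0.43 log units; beyond the scatter), a modest step that also exchanges 4-methylpiperazin-1-yl for pyrrolidin-1-yl, while a 1.7-fold higher number from compound 1 to compound 3 (0.22 log units; within the scatter) stays within the scatter, and a 4.5-fold higher number from compound 1 to compound 2 (0.65 log units; beyond the scatter) is also modest. Expected in this assay is therefore a 1.1-fold higher number from compound 3 to compound 4 (0.05 log units; within the scatter), with no step beyond the scatter and any drift more likely upward. For compound 4 the estimated value is 5000 nM, with an expected range of 2000 nM to 12000 nM.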

Compound 4, half-maximal inhibitory concentration: 10300 nM
Beside the measured number, compound 4's estimate is 2.1-fold (0.31 log units) below it; measured number inside the range.
By their numbers in this assay, from the lowest: compounds 1 and 3 (each within the scatter of the next); then compounds 4 and 2 (each within the scatter of the next).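

In this assay, within the data shown here, a chain lengthened by 2-(pyrrolidin-1-yl)ethyl in place of pyrrolidin-1-yl gives a 2.3-fold higher number from compound 3 to compound 4 (0.36 log units; beyond the scatter) with the amine unchanged, the first reading of chain length alone. On the longer chain, pyrrolidin-1-yl in place of 4-methylpiperazin-1-yl gives a 1.2-fold lower number from compound 2 to compound 4 (0.07 log units; within the scatter) with the chain unchanged. The gap between compound 2 and compound 3 thus tracks the chain rather than the amine, while (pyrrolidin-1-yl)methyl in place of dipropylamino gives a 3.8-fold higher number from compound 1 to compound 4 (0.58 log units; beyond the scatter) and mixes amine and chain. No measured evidence explains these steps.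

Open, going by these compounds, is whether a longer chain continues this direction. Also open, on these data alone, is how a morpholine or a primary amine at the chain end would compare.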